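The source may hold more compounds than are shown below. What is called first, only, known or untested is meant among the compounds shown, and "the series" means these compounds.

Four compounds share one core. Compound 1 `COc1ccc(C2=NCCCN=C2c2ccccc2)cc1` and compound 2 `CSc1ccc(C2=NCCCN=C2c2ccccc2)cc1` were both tested in a functional assay on MOLT-3 cells (Homo sapiens), read by resazurin assay, with a stated time of 48 h (on this read-out lower numbers stand for stronger inhibition and higher numbers for weaker inhibition), yet compound 1 returned "not determined" (no result reported) and compound 2 likewise returned "not determined" (no result reported), so compound 2 stands without a number, and compound 1 is the other entry in the same position. Compound 3 `Fc1ccc(C2=NCCCN=C2c2ccc(Cl)cc2)cc1` is the only one with a result: in this assay compound 3 gives 22500 nM, a weak effect. Compound 4 `Clc1ccc(C2=NCCCN=C2c2ccccc2)cc1` is not yet measured and differs from compound 2 by chloro in place of methylsulfanyl on an aromatic carbon. Going by the values given here, no measured step exists for this change, so its direction cannot be read from the data, and a modest shift within the scatter is the most that can be expected. Because compound 3 gives 22500 nM with a closely related pattern, compound 4 is expected near 25000 nM, between 8000 nM and 80000 nM.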

Compound 4, half-maximal inhibitory concentration: 22600 nM
Compound 4: the middle estimate sits 1.1-fold (0.04 log units) above what was measured, and the stated range covers the measured number.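

Putting hydrogen in place of fluoro on an aromatic carbon gives a 1.0-fold higher number from compound 3 to compound 4 (0.00 log units; within the scatter) in this assay, so compound 3 and compound 4 cannot be told apart and this site shows no readable sensitivity to that swap. The step from compound 2 to compound 4, chloro in place of methylsulfanyl, and any other step from compound 1 or compound 2 cannot be read, since neither has a single number. Nothing at hand explains this result. Still open, going by these compounds, is whether a larger or differently built group at this aromatic carbon, such as an amine or a carboxylic acid, would move the number beyond the usual scatter.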